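The source may hold more compounds than are shown below. What is called first, only, known or untested is meant among the compounds shown, and "the series" means these compounds.

Measured compounds:
compound 1, `N#Cc1c(Nc2ccccc2Cl)nc(SCc2cn(Cc3ccccc3Cl)nn2)nc1-c1ccccc1`: 8350 nM
compound 2, `N#Cc1c(Nc2ccc(Cl)cc2)nc(SCc2cn(Cc3ccccc3Cl)nn2)nc1-c1ccccc1`: 1590 nM
compound 3, `N#Cc1c(Nc2ccccc2F)nc(SCc2cn(Cc3ccccc3Cl)nn2)nc1-c1ccccc1`: 5230 nM

All three were run in a functional assay on B16-F10 cells (Mus musculus) for inhibition, read by MTT assay, with a stated time of 72 h; a higher number here means a weaker inhibitor, a lower number a stronger inhibitor. Compound 3 stands second highest of the three numbers; nearest is compound 1, with a 1.6-fold lower number from compound 1 to compound 3 (0.20 log units; within the scatter) between them, furthest is compound 2, with a 3.3-fold higher number from compound 2 to compound 3 (0.52 log units; beyond the scatter).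

Compound 4, `Cc1ccccc1Nc1nc(SCc2cn(Cc3ccccc3Cl)nn2)nc(-c2ccccc2)c1C#N`, is not yet measured. It differs from compound 3 by methyl in place of fluoro on an aromatic carbon.

Going by the values given here, the step that bears most directly on this change is the one from compound 1 to compound 3, which also swaps one small group for another at the same aromatic carbon and gave a 1.6-fold lower number from compound 1 to compound 3 (0.20 log units; within the scatter). The other two steps, a 5.3-fold lower number from compound 1 to compound 2 (0.72 log units; beyond the scatter) and a 3.3-fold higher number from compound 2 to compound 3 (0.52 log units; beyond the scatter), move the substituent to another place on the ring and so speak less to a like-for-like swap at one position. On this basis the expected step is a 1.1-fold higher number from compound 3 to compound 4 (0.06 log units; within the scatter), that is nothing beyond the scatter, in either direction.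

Compound 4 is therefore estimated at 6000 nM, within 2500 nM to 15000 nM.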

Compound 4, half-maximal inhibitory concentration: 2760 nM
Compound 4: middle estimate off by 2.2-fold (0.34 log units), on the high side, within the range that was stated.
By their numbers in this assay, from the lowest: compounds 2, 4, 3 and 1 (each within the scatter of the next, the first and the last beyond it).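

In this assay, a carbon substituent on this aromatic carbon, ortho to a large group, separates from chloro but not from fluoro: methyl in place of chloro gives a 3.0-fold lower number from compound 1 to compound 4 (0.48 log units; beyond the scatter), whereas methyl in place of fluoro gives a 1.9-fold lower number from compound 3 to compound 4 (0.28 log units; within the scatter). Compound 3 therefore lies within the scatter of both compound 1 and compound 4, although those two lie beyond it from each other. The 2-methylphenyl group also stands within the scatter of the 4-chlorophenyl group, with a 1.7-fold higher number from compound 2 to compound 4 (0.24 log units; within the scatter), so a substituent at the ortho place does not by itself set a compound beyond the scatter of compound 2, as compound 1 alone might have suggested.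

Nothing shown gives a reason for these steps. Open, as far as these compounds go, is how a methoxy group or an amine on this carbon would read, and whether 4-methylphenyl would stand with 2-methylphenyl.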